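Chlorophenyl thioether in place of dimethylphenyl on the shared core

This account rests on a few compounds, and the source may have more. Where it says the series, first, only, none or still open, it means among the compounds named here.

Measured compounds:
Compound 1 `CC(C)(C)c1ccc(SCc2ccc(C(=O)Nc3ccccc3N)cc2)cc1` gives 38.6%
Compound 2 `Cc1cc(C)cc(SCc2ccc(C(=O)Nc3ccccc3N)cc2)c1` gives 33.3%

In a functional assay on A549 cells (Homo sapiens) for inhibition, read by CCK-8 assay, with a stated time of 72 h, tested at 2 uM (a lower number here means less inhibition of growth, a higher number more inhibition of growth at the concentration tested), compound 1 and compound 2 were both tested, and in this assay compound 2 gives 33.3% while compound 1 gives 38.6%. The two numbers lie within the usual scatter of each other, so neither compound can be set apart from the other on these data; the two are simply alike at the concentration tested.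

Compound 3 `Nc1ccccc1NC(=O)c1ccc(CSc2ccc(Cl)cc2)cc1` has not yet been measured. Its difference from compound 2 is 4-chlorophenyl in place of 3,5-dimethylphenyl on a sulfur. Both compounds keep the same core and the same sulfur linkage to the saturated chain carbon, and only the aryl group on that sulfur differs.

For the measured compounds named here, no step between measured compounds is available to guide the size of this change. Since compound 1 with its 4-tert-butylphenyl group and compound 2 with its 3,5-dimethylphenyl group give numbers within the scatter of each other, compound 3 is expected to land close to compound 2, with a step of a number 1.7 percentage points higher from compound 2 to compound 3 (within the scatter) that does not exceed the scatter in either direction. Compound 3 is therefore estimated at 35%, with a likely range from 22% to 48%.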

Compound 3, percent growth inhibition at one concentration: 47.3%
Estimate against measurement, compound 3: 12.3 percentage points below, within the range that was stated.
By their numbers in this assay, from the lowest: compounds 2, 1 and 3 (each within the scatter of the next, the first and the last beyond it).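

The aryl group on the sulfur turns out not to be neutral in this assay: replacing 3,5-dimethylphenyl with 4-chlorophenyl gives a number 14 percentage points higher from compound 2 to compound 3 (beyond the scatter) and is the only step among these compounds that clears the scatter, though it remains modest. The result does not single out the 4-chlorophenyl group, since chloro in place of tert-butyl on an aromatic carbon gives a number 8.7 percentage points higher from compound 1 to compound 3 (within the scatter) and leaves compound 3 and compound 1 alike at the concentration tested. So the sensitivity of this position rests on a single pair, and nothing available bears on why this change shifts growth inhibition.

The compounds shown leave open whether the step from compound 2 to compound 3 comes from gaining the chlorine or from losing the two methyl groups, a question that a 3,5-dichlorophenyl or 4-methylphenyl group on the sulfur could help to separate. They also leave open how this position would respond to a methoxy group, an amine or a carboxylic acid on that aromatic ring.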